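The source may report more compounds than this note shows. Statements on the series, on what has been measured and on what is new or still open speak of the compounds shown alone.

Measured so far in an ADME assay on Caco-2 cells (Homo sapiens) for permeability, in the apical to basolateral direction; a higher number here means that the compound crosses the layer faster, a lower number that the compound crosses the layer more slowly:

compound 1 `CC(C)NC(=O)N1CCC(CN(C2Cc3cc(C#N)ccc3N(Cc3cncn3C)C2)S(=O)(=O)c2ccccn2)CC1` — 0.6 10^-6 cm/s
compound 2 `Cn1cncc1CN1CC(N(CC2CCN(C(=O)C3CC3)CC2)S(=O)(=O)c2ccccn2)Cc2cc(C#N)ccc21` — 0.5 10^-6 cm/s

Compound 1 gives the higher of the two numbers in this assay, though its step to compound 2, a 1.2-fold lower number from compound 1 to compound 2 (0.08 log units; within the scatter), lies within the scatter, so the two cannot be ordered. The unmeasured compound 3 `CC(C)C(=O)N1CCC(CN(C2Cc3cc(C#N)ccc3N(Cc3cncn3C)C2)S(=O)(=O)c2ccccn2)CC1` differs from compound 1 in one place: isopropyl in place of isopropylamino on a carbonyl carbon. Within the data shown here, the only step of the same kind that has been measured is the one from compound 1 to compound 2, where a cyclopropyl entered in place of the isopropylamino on the same carbonyl carbon; that step was a 1.2-fold lower number from compound 1 to compound 2 (0.08 log units; within the scatter). The change to compound 3 is of the same type, an isopropyl in place of the isopropylamino on that carbonyl carbon, so no step beyond the scatter is expected in this assay; the expected change is a 1.1-fold lower number from compound 1 to compound 3 (0.04 log units; within the scatter). Compound 3 is therefore estimated at 0.55 10^-6 cm/s, with a range of 0.3 10^-6 cm/s to 1.1 10^-6 cm/s.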

Compound 3, apparent permeability: 0.5 10^-6 cm/s
Beside the measured number, compound 3's estimate is 1.1-fold (0.04 log units) above it; the measured number falls inside the stated range.
By their numbers in this assay, from the lowest: compounds 2, 3 and 1 (each within the scatter of the next).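

In this assay, the hydrogen-bond donor of the isopropylamino group on this carbonyl carbon can be lost without a step beyond the scatter: a 1.2-fold lower number from compound 1 to compound 3 (0.08 log units; within the scatter). The open-chain isopropyl and the cyclopropyl on the same carbon also cannot be told apart, with no change at the digits printed from compound 2 to compound 3 (within the scatter), so all three groups tried at this place give numbers within the scatter of one another. Nothing at hand explains why the number stays put at this position.

From the compounds shown here alone, whether any group on this carbonyl carbon can move the number beyond the scatter remains open, for instance a carboxylic acid, an amine or a longer chain. The compounds shown also leave open whether a change elsewhere on the shared core would do so.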